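The source may report more compounds than this note shows. Statements on the series, on what has been measured and on what is new or still open speak of the compounds shown alone.

Measured compounds:
- compound 1 `COc1cc(/C=C/c2ccc(S(N)(=O)=O)cc2)cc(OC)c1` — 14300 nM
- compound 2 `COc1cccc(/C=C/c2ccc(S(N)(=O)=O)cc2)c1` — 3810 nM
- compound 3 `NS(=O)(=O)c1ccc(/C=C/c2ccc(F)cc2)cc1` — 42300 nM

In a functional assay on RPMI-8226 cells (Homo sapiens) for inhibition (a higher number here means a weaker inhibitor of growth, a lower number a stronger inhibitor of growth), compound 3 gives the highest of the three numbers; compound 1 sits nearest and compound 2 furthest from it, each step away from compound 3 beyond the scatter. Compound 4 `NS(=O)(=O)c1ccc(/C=C/c2ccc(O)cc2)cc1` is not yet measured. Its change from compound 3: hydroxy in place of fluoro on an aromatic carbon. Within the data shown here, the only measured step, a 3.8-fold lower number from compound 1 to compound 2 (0.57 log units; beyond the scatter), concerns loss of a methoxy on the other ring and does not cover a hydroxy replacing a fluoro, so no step of the same kind is available. With the shared core otherwise unchanged, a modest downward step in this assay is expected, a 2.8-fold lower number from compound 3 to compound 4 (0.45 log units; beyond the scatter), with wide uncertainty. Compound 4 is estimated at 15000 nM, range 4000 nM to 55000 nM.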

Compound 4, concentration for 50% growth inhibition: 7090 nM
Estimate against measurement, compound 4: 2.1-fold (0.33 log units) above; the range from low to high includes it.
By their numbers in this assay, from the lowest: compounds 2, 4 and 1 (each within the scatter of the next, the first and the last beyond it); then compound 3.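

In this assay, hydroxy in place of fluoro on an aromatic carbon para to a large group gives a 6.0-fold lower number from compound 3 to compound 4 (0.78 log units; beyond the scatter), so the group at this place affects growth inhibition, which the earlier methoxy step on the other ring could not show. The change also adds a hydrogen-bond donor and a hydrogen-bond acceptor, but one pair cannot link either count to the step. Nothing at hand accounts for the step. Open, from the compounds shown here alone, is how an amine or a carboxylic acid at this place would compare with hydroxy and fluoro.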